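Oxan-4-yl in place of methyl on the aromatic nitrogen

The source may hold more compounds than are shown below. What is called first, only, known or untested is meant among the compounds shown, and "the series" means these compounds.

Compound 3 `CN(C)C(=O)CN1CCC(c2cc3c(-c4ccc(=O)n(C)c4)ccnc3[nH]2)CC1` is the reference point. In an ADME assay on cells (Hepatocyte, Rattus norvegicus) for metabolic stability (on this read-out lower numbers stand for slow clearance and higher numbers for fast clearance), compound 3 gives < 1 uL/min, which is a limit of the assay and not a number. Compound 1 `CN(C)C(=O)CN1CCC(c2cc3c(-c4ccc(=O)n(C5CCC5)c4)ccnc3[nH]2)CC1` and compound 2 `CC(C)n1nc(-c2ccnc3[nH]c(C4CCN(CC(=O)N(C)C)CC4)cc23)ccc1=O` give numbers: in this assay compound 1 gives 5.8 uL/min, and compound 2 gives 3.1 uL/min. Both steps into compound 3 run downward, an at least 5.8-fold lower number from compound 1 to compound 3 (0.76 log units; beyond the scatter) and an at least 3.1-fold lower number from compound 2 to compound 3 (0.49 log units; beyond the scatter), and their size is bounded only by the limit of < 1 uL/min in this assay, at which 1 of the 3 values shown sits.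

Compound 4 `CN(C)C(=O)CN1CCC(c2cc3c(-c4ccc(=O)n(C5CCOCC5)c4)ccnc3[nH]2)CC1` differs from compound 3 in one place: oxan-4-yl in place of methyl on an aromatic nitrogen. The measured step that bears on this is an at least 5.8-fold lower number from compound 1 to compound 3 (0.76 log units; beyond the scatter), where methyl replaced cyclobutyl on an aromatic nitrogen. Compound 4 runs the other way, oxan-4-yl entering where methyl leaves, so an upward step of comparable size is expected, with the caveat that the start is a limit. The expected step is an at least 3.5-fold higher number from compound 3 to compound 4 (0.54 log units; beyond the scatter). Compound 4 is therefore estimated at 3.5 uL/min in this assay, within 1.2 uL/min to 9 uL/min.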

Compound 4, intrinsic clearance in a liver preparation (reported as CLH), per the amount of preparation that the assay uses: 2.3 uL/min
Compound 4: the middle estimate sits 1.5-fold (0.18 log units) above what was measured; low and high end bracket the measured number.
By their numbers in this assay, from the lowest: compounds 4, 2 and 1 (each within the scatter of the next, the first and the last beyond it). At a limit, below all of these: compound 3.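

In this assay, oxan-4-yl in place of cyclobutyl on the aromatic nitrogen gives a 2.5-fold lower number from compound 1 to compound 4 (0.40 log units; beyond the scatter), so a ring at this position does not fix the number at the level of compound 1. Against methyl, the same group gives an at least 2.3-fold higher number from compound 3 to compound 4 (0.36 log units; beyond the scatter), which places compound 4 between compound 3 and compound 1 on this read-out. Compound 3 stands at a limit and not a number, so the size of that upward step is bounded from one side only: the limit of < 1 uL/min in this assay, at which 1 of the 4 values shown sits.

On these data alone, whether the ring oxygen or the ring size separates compound 4 from compound 1 stays open, as the two groups differ in both. Cyclohexyl on the same nitrogen, or an amine such as piperidin-4-yl, would bear on that question.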